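A few compounds are considered here, and "the series" means these few. Any claim that something is new, unique, unknown or untested is made for them only; others in the source may bear on it.

Measured compounds in an assay on isolated protein for displacement of a labelled ligand from Gonadotropin-releasing hormone receptor (Rattus norvegicus); a higher number here means a weaker inhibitor, a lower number a stronger inhibitor:
- compound 1 `Cc1nc(C)c(CN2CCN(c3cccc4[nH]c(-c5ccc(C(C)(C)C)cc5)nc34)CC2)o1` gives 740 nM
- compound 2 `CCc1cc(CN2CCN(c3cccc4[nH]c(-c5ccc(C(C)(C)C)cc5)nc34)CC2)n(C)n1` gives 250 nM
- compound 3 `Cc1nc(CN2CCN(c3cccc4[nH]c(-c5ccc(C(C)(C)C)cc5)nc34)CC2)cn1C` gives 34 nM

Compound 2 stands second highest of the three numbers: it sits a 3.0-fold lower number from compound 1 to compound 2 (0.47 log units; beyond the scatter) beneath compound 1, and compound 3 lies well below it, a 7.4-fold lower number from compound 2 to compound 3 (0.87 log units; beyond the scatter).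

Compound 4 `CCc1nc(CN2CCN(c3cccc4[nH]c(-c5ccc(C(C)(C)C)cc5)nc34)CC2)cn1C` is not yet measured. It differs from compound 2 by 2-ethyl-1-methyl-1H-imidazol-4-yl in place of 3-ethyl-1-methyl-1H-pyrazol-5-yl on a saturated chain carbon bound to an amine nitrogen in a ring. The change is the pyrazole-to-imidazole swap already seen in the series, with the ethyl group carried along in place of the methyl of compound 3.

The step that bears most directly on it is a 7.4-fold lower number from compound 2 to compound 3 (0.87 log units; beyond the scatter), a modest gain, and the larger 22-fold lower number from compound 1 to compound 3 (1.34 log units; beyond the scatter) points the same way: the 1,2-dimethyl-1H-imidazol-4-yl headgroup is the lowest number measured. Whether an ethyl in place of a methyl on the imidazole costs or adds anything is not shown by any measured pair, so the expectation rests on the pyrazole-to-imidazole step alone.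

Compound 4 is therefore expected to give a number near that of compound 3, estimated at 45 nM in this assay, within 15 nM to 150 nM, which would mean an expected step of a 5.6-fold lower number from compound 2 to compound 4 (0.74 log units; beyond the scatter).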

Compound 4, half-maximal inhibitory concentration: 78 nM
Beside the measured number, compound 4's estimate is 1.7-fold (0.24 log units) below it, and the stated range covers the measured number.
By their numbers in this assay, from the lowest: compound 3; then compound 4; then compound 2; then compound 1.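

In this assay, among these compounds, a 2.3-fold higher number from compound 3 to compound 4 (0.36 log units; beyond the scatter) gives the first direct reading of this change: methyl in place of hydrogen on a saturated chain carbon bound to an aromatic carbon, which turns the methyl on the imidazole into an ethyl, costs a modest but real amount of binding. The imidazole headgroup keeps its lead with the ethyl group in place, with a 3.2-fold lower number from compound 2 to compound 4 (0.51 log units; beyond the scatter) between two headgroups that have the same atoms joined differently, and a 9.5-fold lower number from compound 1 to compound 4 (0.98 log units; beyond the scatter), so the order imidazole, pyrazole, oxazole holds for these compounds whichever alkyl group the imidazole carries. Nothing available explains either the cost of the added methyl or the difference between the two ethyl-bearing rings.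

Open, on these data alone, is whether a propyl or cyclopropyl group in place of the ethyl of compound 4 would raise the number further, or whether a hydrogen in place of the methyl of compound 3 would lower it. Also open, as far as these compounds go, is whether a methyl in place of the ethyl of compound 2 would improve the pyrazole as it does the imidazole, which would show if the alkyl effect carries across headgroups.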